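A few compounds are considered here, and "the series" means these few. Any claim that something is new, unique, unknown or untested is made for them only; others in the source may bear on it.

Measured so far: compound 1 `CC(C)C(=O)N1CCC[C@H]1C(=O)N1CCC(NS(=O)(=O)c2cc(S(=O)(=O)c3ccccc3)ccc2C(F)(F)F)CC1` gives 90 nM in a functional assay on U2OS cells for antagonist activity at proto-oncogene Wnt-3 (Homo sapiens), read by a luciferase reporter, with a stated time of 18 h; a lower number here means that less compound is needed, a higher number that more compound is needed for the effect; compound 2 `CC(C)(C)NC(=O)N1CCC[C@H]1C(=O)N1CCC(NS(=O)(=O)c2cc(S(=O)(=O)c3ccccc3)ccc2C(F)(F)F)CC1` gives 30 nM; compound 3 `O=C([C@@H]1CCCN1C(=O)Nc1ccccc1)N1CCC(NS(=O)(=O)c2cc(S(=O)(=O)c3ccccc3)ccc2C(F)(F)F)CC1` gives 310 nM.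

Compound 3 stands at the highest number of the three: a 3.4-fold higher number from compound 1 to compound 3 (0.54 log units; beyond the scatter) and a 10-fold higher number from compound 2 to compound 3 (1.01 log units; beyond the scatter). Compound 4 `O=C([C@@H]1CCCN1Cc1ccccc1)N1CCC(NS(=O)(=O)c2cc(S(=O)(=O)c3ccccc3)ccc2C(F)(F)F)CC1` differs from compound 3 in one place: benzyl in place of phenylcarbamoyl on an amine nitrogen in a ring. Among the compounds with values here, no measured step exchanges the whole carbonyl-bearing group on this ring nitrogen for a plain benzyl, so the precedent is only indirect. The two steps ending at compound 3 show that what sits on this nitrogen shifts the number modestly to largely, and the direction of a further change is not fixed by them. For compound 4 a modest rise beyond the scatter is expected, a 2.3-fold higher number from compound 3 to compound 4 (0.35 log units; beyond the scatter). Compound 4 is estimated at 700 nM, with a range of 200 nM to 3000 nM.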

Compound 4, half-maximal effective concentration: 720 nM
The estimate for compound 4 lay 1.0-fold (0.01 log units) below the measured number; low and high end bracket the measured number.
By their numbers in this assay, from the lowest: compound 2; then compound 1; then compound 3; then compound 4.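

In this assay, replacing the carbonyl-bearing groups on this amine nitrogen in a ring with benzyl raises the number in every case (a 2.3-fold higher number from compound 3 to compound 4 (0.37 log units; beyond the scatter); an 8.0-fold higher number from compound 1 to compound 4 (0.90 log units; beyond the scatter); a 24-fold higher number from compound 2 to compound 4 (1.38 log units; beyond the scatter)). Compound 4 therefore stands above all three carbonyl-bearing compounds, and the step is smallest from the phenylcarbamoyl group, which also carries a six-membered aromatic ring. Nothing available explains these rises.

Still open, going by these compounds, is where a methanesulfonyl group, an acetyl group or the free ring amine would fall on this nitrogen, relative to compound 2 and compound 4.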